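Lengthening a Linker Chain and Cytotoxicity in Rat Cells

This account rests on a few compounds, and the source may have more. Where it says the series, first, only, none or still open, it means among the compounds named here.

Compound 1 `c1ccc(OCCCCOc2cccc(-c3cc4cc(C5=NCCN5)ccc4o3)c2)cc1` was tested in an ADME assay on L6 cells (Rattus norvegicus) for cytotoxicity, read by resazurin assay, with a stated time of 70 h (a lower number here means a stronger inhibitor, a higher number a weaker inhibitor), where compound 1 gives 9500 nM. Compound 3 `c1ccc(OCCCCCOc2cccc(-c3cc4cc(C5=NCCN5)ccc4o3)c2)cc1` differs from compound 1 only by phenoxymethyl in place of phenoxy on a saturated chain carbon, four bonds along the chain from an oxygen on an aromatic ring. In this assay compound 3 gives 2600 nM, which amounts to a 3.7-fold lower number from compound 1 to compound 3 (0.56 log units; beyond the scatter). Compound 2 `N=C(N)c1ccc2oc(-c3cccc(OCCCCCOc4ccccc4)c3)cc2c1` rests on a different core, and the difference between the two cores is not broken down here; in this assay compound 2 gives 3000 nM. Set against compound 3, this is a 1.2-fold lower number from compound 2 to compound 3 (0.06 log units; within the scatter).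

Compound 4 `N=C(N)c1ccc2oc(-c3cccc(OCCCCCCOc4ccccc4)c3)cc2c1` has not yet been measured. It differs from compound 2 by phenoxymethyl in place of phenoxy on a saturated chain carbon, five bonds along the chain from an oxygen on an aromatic ring. The same kind of change was made from compound 1 to compound 3, but there the place was four bonds along the chain from an oxygen on an aromatic ring, while here it is five bonds along the chain. For compound 4 the expected step is a 2.0-fold lower number from compound 2 to compound 4 (0.30 log units; within the scatter), a somewhat smaller shift than the measured 3.7-fold lower number from compound 1 to compound 3 (0.56 log units; beyond the scatter), since the core and the place both differ. Compound 4 is therefore expected to give about 1500 nM, most likely between 600 nM and 4500 nM.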

Compound 4, half-maximal inhibitory concentration: 3100 nM
Compound 4: the middle estimate sits 2.1-fold (0.32 log units) below what was measured; measured number inside the range.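

On the core of compound 2, the step from phenoxy to phenoxymethyl in this assay reads a 1.0-fold higher number from compound 2 to compound 4 (0.01 log units; within the scatter), so these two numbers cannot be told apart. The same change therefore did not carry over at the same size from one core to the other, and the gap between the two steps is larger than repeat measurements would explain: the same change on two cores in this assay, a 3.7-fold lower number (0.56 log units; beyond the scatter) from compound 1 to compound 3 and a 1.0-fold higher number (0.01 log units; within the scatter) from compound 2 to compound 4, 3.8-fold (0.58 log units) apart, beyond the scatter of two such steps. This does not show why the steps differ, since the pairs differ in both core and place, four bonds along the chain in one and five in the other, and a single pair on each core cannot separate these two factors.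

The compounds shown leave open what the same change does at five bonds along the chain on the core of compound 1, and at four bonds on the core of compound 2. They also leave open whether a longer chain, or an amine at the end of the chain in place of the phenoxy group, would shift the numbers on either core.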